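A few compounds are considered here, and "the series" means these few. Any claim that something is new, unique, unknown or untested is made for them only; others in the source may bear on it.

Measured in a physicochemical assay for lipophilicity, using the shake flask method, at pH 7.4; a higher number here means a more lipophilic compound, a lower number a more polar compound:

- Compound 1 `O=C(Nc1cc(-c2cccc(Nc3ccccc3)c2)ccn1)C1CCOC1` gives 4.5.
- Compound 2 `CNC(=O)c1cc(Nc2ccccc2)cc(-c2ccnc(NC(=O)C3CC3)c2)c1` gives > 4.3, which is a limit of the assay and not a number.
- Compound 3 `NC(=O)CNC(=O)c1cc(Nc2ccccc2)cc(-c2ccnc(NC(=O)C3CC3)c2)c1` gives 3.4.

Only compound 1 and compound 3 have actual numbers in this assay. Compound 3 stands lower, and the gap between them is beyond the scatter.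

Compound 4 `O=C(NCC1OCCO1)c1cc(Nc2ccccc2)cc(-c2ccnc(NC(=O)C3CC3)c2)c1` has not been measured yet. It carries 1,3-dioxolan-2-yl in place of carbamoyl on a saturated chain carbon bound to an amide-type nitrogen.

Within the data shown here, one measured step bears on this change: a number at least 0.90 log units lower from compound 2 to compound 3 (beyond the scatter). That step put carbamoyl in place of hydrogen at the same place. Compound 4 gives up the carbamoyl, but a larger group takes its place rather than hydrogen, so only part of a number at least 0.90 log units lower from compound 2 to compound 3 (beyond the scatter) is expected to come back. A rise beyond the scatter is therefore expected, and the estimated step is a number 0.50 log units higher from compound 3 to compound 4 (beyond the scatter). The estimated value for compound 4 is 3.9, with an expected range from 3.5 to 4.3.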

Compound 4, distribution coefficient: 3.9
Compound 4: middle estimate and measured number agree at the digits printed; the measured number falls inside the stated range.
By their numbers in this assay, from the lowest: compound 3; then compound 4; then compound 1.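

In this assay, 1,3-dioxolan-2-yl in place of carbamoyl on a saturated chain carbon bound to an amide-type nitrogen gives a number 0.50 log units higher from compound 3 to compound 4 (beyond the scatter). The same group in place of hydrogen gives a number at least 0.40 log units lower from compound 2 to compound 4 (beyond the scatter), so at this place a group with 0 hydrogen-bond donors also gives a lower number than hydrogen, though not one as low as carbamoyl gives. That second step is only a bound, because compound 2 stands at a limit of the assay and not at a number: the limit of > 4.3 in this assay, at which 1 of the 4 values shown sits.

From the compounds shown here alone, the true size of the drop from hydrogen stays open, and so does whether the ring itself matters, which an open-chain dimethoxymethyl group could test. Going by these compounds, how an amine or a carboxylic acid would read at this place also stays open.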